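Imidazole to Pyrazole on a Shared Core

The source may hold more compounds than are shown below. What is called first, only, known or untested is meant among the compounds shown, and "the series" means these compounds.

Measured in a physicochemical assay for lipophilicity, using the shake flask method, in phosphate buffer, measured as octanol-water partition, with a stated time of 30 min, at pH 7.4; a higher number here means a more lipophilic compound, a lower number a more polar compound:
Compound 1 `Cc1ncc(-c2cnc(NCc3c(F)ccc4c3CCO4)c3cn[nH]c(=O)c23)n1C` gives 1.9
Compound 2 `O=C1CC2(CC2)CN1c1cnc(NCc2c(F)ccc3c2CCO3)n2cnnc12` gives 1.9

Compound 1 stands level with compound 2 at the digits shown, within the scatter, so these two values show no difference between them. Compound 3 `Cc1nn(C)cc1-c1cnc(NCc2c(F)ccc3c2CCO3)c2cn[nH]c(=O)c12` has not been measured yet. It differs from compound 1 in one place: 1,3-dimethyl-1H-pyrazol-4-yl in place of 1,2-dimethyl-1H-imidazol-5-yl on an aromatic carbon. For the measured compounds named here, no measured step of this kind is known here, so the change from compound 1 to compound 3 is expected to be small, a slight rise at most, close to the scatter. Compound 3 is estimated at 2.2, within 1.7 to 2.7, an expected step of a number 0.30 log units higher from compound 1 to compound 3 (within the scatter).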

Compound 3, distribution coefficient: 2.8
The estimate for compound 3 lay 0.60 log units below the measured number; the measured number lies above the stated range.
By their numbers in this assay, from the lowest: compounds 1 and 2 (each within the scatter of the next); then compound 3.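

In this assay, 1,3-dimethyl-1H-pyrazol-4-yl in place of 1,2-dimethyl-1H-imidazol-5-yl on this aromatic carbon gives a number 0.90 log units higher from compound 1 to compound 3 (beyond the scatter), so the read-out at this position responds to how the ring atoms are joined, even though the two groups hold the same atoms. No measurement available here explains why these two arrangements part. The compounds shown leave open what an amine or a carboxylic acid on this aromatic carbon would give, and whether the same exchange would produce a similar step on another core.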